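Amide for Benzyl on the Central Amine of Compound 1

A few compounds are considered here, and "the series" means these few. Any claim that something is new, unique, unknown or untested is made for them only; others in the source may bear on it.

Measured so far:
compound 1, `C[C@@H](NC(=O)[C@H](CCCNC(=N)N)NC(=O)c1ccc(CN(Cc2ccc(F)cc2)Cc2ccccn2)cc1)c1cccc2ccccc12`: 35000 nM
compound 2, `C[C@@H](NC(=O)[C@H](CCCNC(=N)N)NC(=O)c1ccc(CN(Cc2ccc(F)cc2)Cc2cccnc2)cc1)c1cccc2ccccc12`: 37000 nM

Of the compounds shown here, two have been tested in an ADME assay on MT4 cells (Homo sapiens) for cytotoxicity; a lower number here means that less compound is tolerated, a higher number that more compound is tolerated. For the measured compounds named here, compound 1 gives 35000 nM and compound 2 gives 37000 nM; compound 1 thus holds the lowest of the two numbers, and the only step recorded, a 1.1-fold higher number from compound 1 to compound 2 (0.02 log units; within the scatter), lies within the scatter, so the two values are to be read as the same.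

Compound 3 `C[C@@H](NC(=O)[C@H](CCCNC(=N)N)NC(=O)c1ccc(CN(Cc2ccccn2)C(=O)c2ccc(F)cc2)cc1)c1cccc2ccccc12` is not yet measured. It differs from compound 1 in one place: (4-fluorophenyl)carbonyl in place of 4-fluorobenzyl on an amine nitrogen. Going by the values given here, no measured step touches this change. Among the compounds with values here, the single step available, a 1.1-fold higher number from compound 1 to compound 2 (0.02 log units; within the scatter), concerns a different group on the same amine nitrogen and is uninformative about swapping a benzyl for a carbonyl-linked ring. With nothing to point in either direction, the author expects no step beyond the scatter, that is no change at the digits printed from compound 1 to compound 3 (within the scatter), while granting a wide band given the lack of any relevant comparison. For compound 3 the estimate in this assay is therefore 35000 nM, within a range of 12000 nM to 100000 nM.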

Compound 3, half-maximal cytotoxic concentration: 38000 nM
Compound 3: middle estimate off by 1.1-fold (0.04 log units), on the low side; the measured number falls inside the stated range.
By their numbers in this assay, from the lowest: compounds 1, 2 and 3 (each within the scatter of the next).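

In this assay, placing (4-fluorophenyl)carbonyl in place of 4-fluorobenzyl on the amine nitrogen of compound 1 gives a 1.1-fold higher number from compound 1 to compound 3 (0.04 log units; within the scatter), so the two values are to be read as the same. For the compounds shown here, this is the first step at this substituent of the amine nitrogen, and it shows that the read-out stays within the scatter even when a carbonyl enters the group, with its hydrogen-bond acceptor, while the six-membered aromatic ring and its fluorine remain. Together with a 1.1-fold higher number from compound 1 to compound 2 (0.02 log units; within the scatter), it means that a change to either of two substituents on this nitrogen has so far left the number within the scatter, and no evidence is available that would explain this tolerance.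

As far as these compounds go, it remains open whether a group of another kind on this nitrogen, such as a carboxylic acid, a primary amine or a longer alkyl chain in place of the 4-fluorobenzyl, would also stay within the scatter of compound 1 in this assay. From the compounds shown here alone, it is equally open whether the fluorine plays any part in these numbers, as a plain benzyl or a chlorine in its place would show.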